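This account rests on a few compounds, and the source may have more. Where it says the series, first, only, none or still open, it means among the compounds named here.

Compounds measured so far:
compound 1 `Cc1ccc(C(=O)Oc2ccc(Cl)cc2C(=O)Nc2ccc(Cl)c(Cl)c2)cc1` gives 2550 nM
compound 2 `Cc1ccc(C(=O)Oc2ccc(Cl)cc2C(=O)Nc2ccc(C(F)(F)F)cc2)cc1` gives 6900 nM
compound 3 `O=C(Oc1ccc(Cl)cc1C(=O)Nc1ccc(C(F)(F)F)cc1)c1ccc(Br)cc1` gives 14500 nM

These three compounds were measured in a functional assay on HepG2 cells (Homo sapiens), read by MTT assay, with a stated time of 72 h; a lower number here means a stronger inhibitor, a higher number a weaker inhibitor. Compound 1 stands at the lowest number of the three; its nearest neighbour is compound 2, and the step of a 2.7-fold higher number from compound 1 to compound 2 (0.43 log units; beyond the scatter) is a modest rise that lies beyond the scatter. Compound 3 stands furthest from compound 1, and the step of a 2.1-fold higher number from compound 2 to compound 3 (0.32 log units; beyond the scatter) adds a further modest rise beyond the scatter.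

Compound 4 `O=C(Oc1ccc(Cl)cc1C(=O)Nc1ccc(Cl)c(Cl)c1)c1ccc([N+](=O)[O-])cc1` has not yet been measured. It differs from compound 1 by nitro in place of methyl on an aromatic carbon. Of the two measured steps, only the change from compound 2 to compound 3 bears on this one, since it also replaces the methyl on an aromatic carbon, and it gave a 2.1-fold higher number from compound 2 to compound 3 (0.32 log units; beyond the scatter). The step from compound 1 to compound 2 alters a different part of the molecule and says little here. Because a 2.1-fold higher number from compound 2 to compound 3 (0.32 log units; beyond the scatter) was a modest rise, a rise of similar size is expected in this assay for compound 4, giving the expected step of a 2.0-fold higher number from compound 1 to compound 4 (0.29 log units; within the scatter). Compound 4 is therefore estimated at 5000 nM, with a range from 2000 nM to 13000 nM.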

Compound 4, half-maximal inhibitory concentration: 3550 nM
Compound 4: middle estimate off by 1.4-fold (0.15 log units), on the high side; the range from low to high includes it.
By their numbers in this assay, from the lowest: compounds 1, 4 and 2 (each within the scatter of the next, the first and the last beyond it); then compound 3.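

In this assay, nitro in place of methyl gives a 1.4-fold higher number from compound 1 to compound 4 (0.14 log units; within the scatter), so at this aromatic carbon, para to a large group, a swap that brings in three heavy atoms and two hydrogen-bond acceptors where methyl had one heavy atom and no acceptors leaves compound 1 and compound 4 indistinguishable. Going by these compounds alone, until now, the only change at this position was bromo in place of methyl, made on the compounds carrying 4-(trifluoromethyl)phenyl, and it gave a 2.1-fold higher number from compound 2 to compound 3 (0.32 log units; beyond the scatter); compound 4 adds the finding that a change here, on the compounds carrying 3,4-dichlorophenyl, need not move the number beyond the scatter. Nothing measured here offers an explanation for this result.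

The compounds shown leave open how an amine or a carboxylic acid would read at this same position. They also leave open whether nitro would give a similar result on the compounds carrying 4-(trifluoromethyl)phenyl, and whether bromo would do so on the compounds carrying 3,4-dichlorophenyl.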